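The compounds below may be only part of what the source reports. "The series", "measured", "known", "first", "only" and "open" are said of these compounds alone.

Measured so far:
compound 1, `O=C([C@@H]1C[C@H](Nc2ccccc2)CN1)N1CCSC1` — 190 nM
compound 2, `CN(Cc1ccc(C#N)cc1)[C@@H]1CN[C@H](C(=O)N2CCSC2)C1` — 13.6 nM

Of the compounds shown here, two have been tested in an assay on a cell-free system (plasma) for inhibition of Dipeptidyl peptidase 4 (Rattus norvegicus), read by fluorescence; on this read-out lower numbers stand for stronger inhibition and higher numbers for weaker inhibition. Compound 1 gives 190 nM, while compound 2 gives 13.6 nM. Among the compounds with values here, compound 2 therefore holds the lower of the two numbers, and its only neighbour, compound 1, stands at a markedly higher number, a gap that lies beyond the usual scatter of this assay.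

The next compound to be tested is compound 3, `N#Cc1ccc(CN(CC(=O)O)[C@@H]2CN[C@H](C(=O)N3CCSC3)C2)cc1`. It differs from compound 2 in one place only: carboxy in place of hydrogen on a saturated chain carbon bound to an amine nitrogen. Within the data shown here, no pair of measured compounds shows a step of this kind, so nothing in the present numbers sets its size directly. With no such reference, the author treats the change as one that is likely to move the number only modestly, if at all, and leans slightly toward a weaker result.

On that basis, compound 3 is expected to show a step of a 1.8-fold higher number from compound 2 to compound 3 (0.26 log units; within the scatter) in this assay. Compound 3 is accordingly estimated at 25 nM, with a range from 6 nM to 100 nM.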

Compound 3, half-maximal inhibitory concentration: 16.3 nM
Estimate against measurement, compound 3: 1.5-fold (0.19 log units) above, within the range that was stated.
By their numbers in this assay, from the lowest: compounds 2 and 3 (each within the scatter of the next); then compound 1.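

In this assay, within the data shown here, carboxy in place of hydrogen on a saturated chain carbon bound to an amine nitrogen gives a 1.2-fold higher number from compound 2 to compound 3 (0.08 log units; within the scatter), the first reading of any change at this position. The same difference, read one bond further out as methyl to carboxymethyl, therefore leaves the number for compound 3 within the scatter of the number for compound 2, so this position accepts the added carboxy group, with its extra heavy atoms, a hydrogen-bond donor and a hydrogen-bond acceptor, without a change that this read-out can resolve. No supporting measurement is available to explain why this step stays so small.

Still open, going by these compounds, is whether the same holds for a longer chain ending in carboxy, for a methyl ester or a primary amide in place of the carboxylic acid, or for an amine at the end of the chain. Also open is whether this single step would carry over to other groups on the same nitrogen, such as one in place of the 4-cyanobenzyl group, since the compounds shown give only this one pair.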